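A Pyrazole Side Chain in a Flat Series

A few compounds are considered here, and "the series" means these few. Any claim that something is new, unique, unknown or untested is made for them only; others in the source may bear on it.

In a functional assay on a cell-free system (plasma, Homo sapiens), with a stated time of 3 min (a higher number here means a weaker inhibitor, a lower number a stronger inhibitor), compound 1 (`O=C(NCc1cc(Cl)ccc1-n1cnnn1)[C@@H]1[C@H]2C[C@H]2CN1C(=O)[C@H](O)c1ccccc1`) gives 960 nM, compound 2 (`O=C(NCc1cc(Cl)ccc1-n1cnnn1)[C@@H]1[C@H]2C[C@H]2CN1C(=O)[C@H](O)Cc1ccccc1`) gives 1200 nM and compound 3 (`O=C(NCc1cc(Cl)ccc1-n1cnnn1)[C@@H]1[C@H]2C[C@H]2CN1C(=O)[C@H](O)C1CCCCC1`) gives 850 nM, so compound 3 stands level with the other two. Compound 4 (`O=C(NCc1cc(Cl)ccc1-n1cnnn1)[C@@H]1[C@H]2C[C@H]2CN1C(=O)[C@H](O)Cn1cccn1`) has (1H-pyrazol-1-yl)methyl in place of cyclohexyl on the saturated chain carbon bound to a carbonyl carbon and an oxygen: (1H-pyrazol-1-yl)methyl in place of cyclohexyl on a saturated chain carbon bound to a carbonyl carbon and an oxygen on a saturated carbon. Three measured steps changed this same place: a 1.3-fold higher number from compound 1 to compound 2 (0.10 log units; within the scatter), a 1.1-fold lower number from compound 1 to compound 3 (0.05 log units; within the scatter) and a 1.4-fold lower number from compound 2 to compound 3 (0.15 log units; within the scatter). All stayed within the scatter, although none brought in a ring with hetero atoms, so the range is kept wide. The expected change is small, a 1.2-fold higher number from compound 3 to compound 4 (0.07 log units; within the scatter), and no step beyond the scatter is expected. Compound 4 is estimated at 1000 nM, within an expected range of 400 nM to 2500 nM.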

Compound 4, half-maximal inhibitory concentration: 1800 nM
Compound 4: the middle estimate sits 1.8-fold (0.26 log units) below what was measured, within the range that was stated.
By their numbers in this assay, from the lowest: compounds 3, 1, 2 and 4 (each within the scatter of the next, the first and the last beyond it).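

In this assay, this position gives its first step beyond the scatter when (1H-pyrazol-1-yl)methyl replaces cyclohexyl (a 2.1-fold higher number from compound 3 to compound 4 (0.33 log units; beyond the scatter)). Against the phenyl and benzyl compounds, the five-membered aromatic ring with 2 hetero atoms stays within the scatter (a 1.9-fold higher number from compound 1 to compound 4 (0.27 log units; within the scatter); a 1.5-fold higher number from compound 2 to compound 4 (0.18 log units; within the scatter)). The position therefore accepts this ring with little change, and only the comparison with cyclohexyl separates the values.

Whether an amine or a carboxylic acid on this saturated chain carbon would give a larger step remains open, and nothing available here explains the step from cyclohexyl.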